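This account rests on a few compounds, and the source may have more. Where it says the series, first, only, none or still open, it means among the compounds named here.

Measured in a functional assay on MOLM-13 cells (Homo sapiens) for antiproliferative activity; a higher number here means a weaker inhibitor, a lower number a stronger inhibitor:

- Compound 1 `Cc1c(-c2ccc(-c3ccccc3F)cc2)nc2ccc(F)cc2c1-c1nnn[nH]1`: > 3000 nM
- Compound 2 `Cc1c(-c2ccc(-c3ccccc3F)cc2)nc2ccc(F)cc2c1-c1noc(=O)[nH]1`: > 3000 nM
- Compound 3 `Cc1c(-c2ccc(-c3ccccc3F)cc2)nc2ccc(F)cc2c1C(=O)NS(C)(=O)=O`: 300 nM

Compound 1 is reported as > 3000 nM, which is a limit of the assay and not a number. Compound 2 is reported as > 3000 nM, which is also a limit. Within the data shown here, that leaves compound 3, at 300 nM, as the only compound here with an actual number.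

The three share a core and differ in one group on an aromatic carbon. Putting (methylsulfonyl)carbamoyl in place of 1H-tetrazol-5-yl gives an at least 10-fold lower number from compound 1 to compound 3 (1.00 log units; beyond the scatter). The other ring group tells the same story, with an at least 10-fold lower number from compound 2 to compound 3 (1.00 log units; beyond the scatter).

Compound 4 `CCONC(=O)c1c(C)c(-c2ccc(-c3ccccc3F)cc2)nc2ccc(F)cc12` keeps the core and changes only part of that group: ethoxy in place of methylsulfonyl on an amide-type nitrogen. Among the measured compounds shown here, no measured step makes this exact swap, so these two steps are only indirect guides. They show that this group can shift the read-out by a wide margin, and so far only compound 3, at 300 nM, has given a number. Losing the methylsulfonyl is therefore expected to weaken the compound, possibly as far as the limit.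

The expected change is a 6.7-fold higher number from compound 3 to compound 4 (0.82 log units; beyond the scatter). For compound 4 the estimate is 2000 nM, with an expected range from 500 nM to 8000 nM.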

Compound 4, half-maximal inhibitory concentration: 33 nM
Beside the measured number, compound 4's estimate is 61-fold (1.78 log units) above it; the whole stated range lies above it.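

In this assay, putting ethoxy in place of methylsulfonyl on the amide-type nitrogen gives a 9.1-fold lower number from compound 3 to compound 4 (0.96 log units; beyond the scatter), which shows that the methylsulfonyl is not required for activity in this series and that this position can take a group without sulfur. Against the two ring groups, ethoxycarbamoyl gives an at least 90-fold lower number from compound 1 to compound 4 (1.95 log units; beyond the scatter) and an at least 90-fold lower number from compound 2 to compound 4 (1.95 log units; beyond the scatter), a wider gap than compound 3 could show against either ring. Both of these steps are minimum sizes, not exact ones, since each starts from a value that is not a number: the limit of > 3000 nM in this assay, at which 2 of the 4 values shown sit.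

The compounds shown leave open whether the gain comes from the oxygen attached to the amide-type nitrogen or from the ethyl chain, and a methoxy, a longer propoxy chain or a plain amine on that nitrogen would help to separate the two. The step between compound 1 and compound 2 cannot be read, so the two ring groups cannot be ranked against each other.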